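Three methoxy groups on a shared core, all at the ceiling

A few compounds are considered here, and "the series" means these few. Any claim that something is new, unique, unknown or untested is made for them only; others in the source may bear on it.

Compound 1 `COc1ccc(-c2nc3cc(C(C)O)ccc3[nH]2)cc1` gives only the assay limit of >= 100000 nM in an ADME assay on MT4 cells (Homo sapiens) for cytotoxicity, read by MTT assay, with a stated time of 96 h; a higher number here means that more compound is tolerated, a lower number that less compound is tolerated.
Compound 2 `COc1ccc(-c2nc3cc(C(C)O)ccc3[nH]2)c(OC)c1` likewise gives only the limit of >= 100000 nM in this assay.
Compound 3 `COc1ccc(-c2nc3cc(/C(C)=N/O)ccc3[nH]2)c(OC)c1` again gives only the limit of >= 100000 nM in this assay.

The change from compound 1 to compound 2 is methoxy in place of hydrogen on an aromatic carbon. The same kind of change links compound 3 to the unmeasured compound 4 `COc1ccc(-c2nc3cc(/C(C)=N/O)ccc3[nH]2)c(OC)c1OC`, namely (methoxy in place of hydrogen on an aromatic carbon); the surroundings differ, since in compound 2 the entering methoxy sits ortho to a large group and meta to a methoxy group, while in compound 4 it sits ortho to two methoxy groups and meta to a large group. The difference between the cores of compound 1 and compound 3 is not broken down here.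

The measured step was a step that the two limits leave unreadable from compound 1 to compound 2, and the following one was a step that the two limits leave unreadable from compound 2 to compound 3, both unreadable because of the limit of >= 100000 nM in this assay, at which 3 of the 3 values shown sit. With every measured value a limit, the data give no readable size for the effect of adding a methoxy.

Compound 3 stands at a limit, >= 100000 nM. The step from compound 3 to compound 4 is therefore estimated as a number no higher from compound 3 to compound 4 (the limit leaves the size open), resting on the unreadable a step that the two limits leave unreadable from compound 1 to compound 2. For compound 4 the expected value is 100000 nM, estimated to lie between 50000 nM and 300000 nM, most likely reported again only as a limit.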

Compound 4, half-maximal cytotoxic concentration: 51000 nM
Beside the measured number, compound 4's estimate is 2.0-fold (0.29 log units) above it; the measured number falls inside the stated range.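

In this assay, methoxy in place of hydrogen on the core of compound 3, on an aromatic carbon ortho to two methoxy groups and meta to a large group, gives an at least 1.9-fold lower number from compound 3 to compound 4 (0.29 log units; that floor lies within the scatter), and a floor of that size does not on its own show a real change. As far as these compounds go, compound 3 gives >= 100000 nM, which is a limit and not a number, and the true size of the step stays open. The same methoxy change on the core of compound 1 and the step that follows it cannot be read, and no comparison of the change between the two cores can be drawn, because those steps rest on limits: the limit of >= 100000 nM in this assay, at which 3 of the 4 values shown sit.

The compounds shown leave open whether an amine, a carboxylic acid or a longer chain on that aromatic carbon, in place of the methoxy, would move the number in this assay. They also leave open whether a methoxy placed in the same way on the core of compound 1 would give a readable number there, and whether the change behaves alike on both cores.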